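Methoxy Enters the Phenyl Ring of Compound 3

A few compounds are considered here, and "the series" means these few. Any claim that something is new, unique, unknown or untested is made for them only; others in the source may bear on it.

Compound 1, `CC1=C(C(=O)OCc2ccccn2)C(c2ccc(Br)cc2)C2=C(CCCC2=O)N1`: 2.42
Compound 2, `CC1=C(C(=O)OCc2ccccn2)C(c2ccc(Cl)cc2)C2=C(CCCC2=O)N1`: 2.24
Compound 3, `CC1=C(C(=O)OCc2cccnc2)C(c2ccccc2)C2=C(CCCC2=O)N1`: 2.35

Of the compounds shown here, three sharing one core have been measured in a physicochemical assay for lipophilicity, measured as octanol-water partition; on this read-out lower numbers stand for lower lipophilicity and higher numbers for higher lipophilicity. Among the measured compounds shown here, the spread among them is small: the one measured step, a number 0.18 log units lower from compound 1 to compound 2 (within the scatter), is within the scatter. Compound 3 stands with the other two; its number differs from that of compound 1 and from that of compound 2 by less than the scatter, so no order among the three can be read from these figures.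

Compound 4, `COc1ccc(C2C(C(=O)OCc3cccnc3)=C(C)NC3=C2C(=O)CCC3)cc1`, has not yet been measured. It differs from compound 3 in one place: methoxy in place of hydrogen on an aromatic carbon. For the measured compounds named here, no measured step adds a methoxy to any compound of this set; the only step available, the chloro-for-bromo exchange from compound 1 to compound 2, touches a different group and was itself within the scatter. It therefore offers no direct guide, and the expectation for compound 4 rests only on the narrow band in which compounds 1, 2 and 3 sit. The step from compound 3 to compound 4 is expected to be a number 0.05 log units lower from compound 3 to compound 4 (within the scatter), that is, nothing beyond the scatter in this assay. Compound 4 is accordingly estimated at 2.3, in the range 2 to 2.6.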

Compound 4, partition coefficient: 1.54
Compound 4: the middle estimate sits 0.76 log units above what was measured, outside the stated range (below it).
By their numbers in this assay, from the lowest: compound 4; then compounds 2, 3 and 1 (each within the scatter of the next).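

In this assay the exchange of hydrogen for methoxy on an aromatic carbon, para to a large group, produces a number 0.81 log units lower from compound 3 to compound 4 (beyond the scatter). The earlier step in the set, chloro in place of bromo on an aromatic carbon, gave a number 0.18 log units lower from compound 1 to compound 2 (within the scatter), so only with phenyl to 4-methoxyphenyl does a single change in these compounds move the partition reading past the scatter, and this position of the ring is thereby shown to be one where a substituent can matter. Nothing at hand offers a reason for the size of this step.

Whether the step belongs to methoxy in particular remains open, since the compounds shown do not compare it on the same scaffold with a hydroxy group, an ethoxy group, an amine or a halogen at this carbon. From the compounds shown here alone, it is equally open whether methoxy would give a step of similar size with the ester of compound 1, and whether it would do so on another carbon of the same ring.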